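This account rests on a few compounds, and the source may have more. Where it says the series, first, only, none or still open, it means among the compounds named here.

Working notes on the series.

Compound 1 `C=C(Cl)C(=O)Nc1cc(Nc2nc3c(c(-c4cn(C)c5ccc(F)cc45)n2)CSCC3)c(OC)cc1N(C)CCN(C)C` and compound 2 `COc1cc(N(C)CCN(C)C)c(NC(=O)C=C(C)C)cc1Nc1nc2c(c(-c3cn(C)c4ccc(F)cc34)n1)CSCC2` share one core. In a functional assay on A549 cells (Homo sapiens) for inhibition, read by MTT assay, with a stated time of 72 h (a lower number here means a stronger inhibitor, a higher number a weaker inhibitor), compound 1 gives 864 nM and compound 2 gives 902 nM. The change between them is 2-methylprop-1-en-1-yl in place of 1-chloroethenyl on a carbonyl carbon and its step is a 1.0-fold higher number from compound 1 to compound 2 (0.02 log units; within the scatter). Compound 3 `C=C(Cl)C(=O)Nc1cc(Nc2nc3c(c(-c4cn(C)c5ccc(F)cc45)n2)CS(=O)(=O)CC3)c(OC)cc1N(C)CCN(C)C` carries the other core; the difference between the two cores is not broken down here. In this assay compound 3 gives 3180 nM, the highest of the three numbers, and its gaps to compound 2 and to compound 1 both lie beyond the scatter.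

Compound 4 `COc1cc(N(C)CCN(C)C)c(NC(=O)C=C(C)C)cc1Nc1nc2c(c(-c3cn(C)c4ccc(F)cc34)n1)CS(=O)(=O)CC2` is not yet measured. It differs from compound 3 by 2-methylprop-1-en-1-yl in place of 1-chloroethenyl on a carbonyl carbon, the same change that was made from compound 1 to compound 2. Going by the values given here, since that earlier step was a 1.0-fold higher number from compound 1 to compound 2 (0.02 log units; within the scatter) and within the scatter, compound 4 is expected to move by about a 1.0-fold higher number from compound 3 to compound 4 (0.02 log units; within the scatter), a step that rests on the one earlier pair only. Compound 4 is therefore estimated at 3300 nM in this assay. The expected span for compound 4 runs from 1600 nM to 6800 nM.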

Compound 4, half-maximal inhibitory concentration: 2140 nM
Compound 4: the middle estimate sits 1.5-fold (0.19 log units) above what was measured, within the range that was stated.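

In this assay, 2-methylprop-1-en-1-yl in place of 1-chloroethenyl on a carbonyl carbon gives a 1.5-fold lower number from compound 3 to compound 4 (0.17 log units; within the scatter), and the two steps do not differ beyond the scatter: the same change on two cores in this assay, a 1.0-fold higher number (0.02 log units; within the scatter) from compound 1 to compound 2 and a 1.5-fold lower number (0.17 log units; within the scatter) from compound 3 to compound 4, 1.6-fold (0.19 log units) apart, within the scatter of two such steps. On both cores shown, exchanging these two groups therefore leaves the number within the scatter, and the step carries from the core of compound 1 to the core of compound 3 without a detectable difference. This rests on two pairs in one assay, so it does not show that the change would behave the same way on any other core or in any other assay, and it does not explain why the two groups read alike.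

The compounds shown leave open how the number responds to other groups on the carbonyl carbon, such as an unsubstituted ethenyl group or a saturated ethyl chain. They also leave open whether the same agreement between cores would hold with a primary amine or a longer chain in place of the dimethylaminoethyl side chain.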